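From compound 2 to compound 3: a one-place change

This account rests on a few compounds, and the source may have more. Where it says the series, first, only, none or still open, it means among the compounds named here.

In an ADME assay on liver for metabolic stability, with Liver microsome (Homo sapiens) as the target, read by LC-MS, using microsomes (a lower number here means slower removal, a higher number faster removal of the compound), the measured compounds read as follows:
- compound 1 `O=C(NCc1cc(Cl)ccc1-n1cnnn1)[C@@H]1CC=NN1C(=O)[C@H](O)Cc1ccccc1` gives < 12 mL.min-1.g-1 as a limit, not a number
- compound 2 `O=C(NCc1cc(Cl)ccc1-n1cnnn1)[C@@H]1[C@H]2C[C@H]2CN1C(=O)[C@H](O)c1ccccc1` gives 61 mL.min-1.g-1 as a number

Among the measured compounds shown here, compound 2 at 61 mL.min-1.g-1 holds the only number so far. Compound 1 gives only a limit (the limit of < 12 mL.min-1.g-1 in this assay, at which 1 of the 2 values shown sits) and no number. Compound 3 `O=C(NCc1cc(Cl)ccc1-n1cnnn1)[C@@H]1[C@H]2C[C@H]2CN1C(=O)[C@H](O)Cc1ccccc1` takes benzyl in place of phenyl on a saturated chain carbon bound to a carbonyl carbon and an oxygen on a saturated carbon. For the measured compounds named here, no measured step covers this change. The step expected in this assay is a 1.2-fold lower number from compound 2 to compound 3 (0.09 log units; within the scatter) and is estimated to stay within the usual scatter. The estimate for compound 3 is 50 mL.min-1.g-1 with an expected range from 18 mL.min-1.g-1 to 120 mL.min-1.g-1 for the coming measurement.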

Compound 3, intrinsic clearance in microsomes: 96 mL.min-1.g-1
Estimate against measurement, compound 3: 1.9-fold (0.28 log units) below, and the stated range covers the measured number.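

In this assay, benzyl in place of phenyl on a saturated chain carbon bound to a carbonyl carbon and an oxygen on a saturated carbon gives a 1.6-fold higher number from compound 2 to compound 3 (0.20 log units; within the scatter). Among the compounds shown here, this is the first readable step at this place, and it shows that hydroxy(phenyl)methyl and 1-hydroxy-2-phenylethyl are not separated by this read-out on the shared core. Nothing measured here bears on a cause for this step.

Open, as far as these compounds go, is what a longer chain or an amine at this place would give. Also open, from the compounds shown here alone, is whether the same step would hold on the core of compound 1.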